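The source may hold more compounds than are shown below. What is called first, only, known or untested is meant among the compounds shown, and "the series" means these compounds.

Measured compounds:
- compound 1, `COc1ccc(-c2ncnc3c2cnn3CCN2CCCCC2)cc1`, 531 nM
- compound 2, `Cc1cc(F)ccc1-c1ncnc2c1cnn2CCN1CCCCC1`, 48 nM

Among the measured compounds shown here, in an assay on HEK293 cells for displacement of a labelled ligand from Sigma non-opioid intracellular receptor 1 (Homo sapiens), read by scintillation counting, with a stated time of 120 min (on this read-out higher numbers stand for weaker inhibition and lower numbers for stronger inhibition), compound 2 gives 48 nM, the lowest of the two numbers so far; the nearest, compound 1, sits well above it, as the step of an 11-fold lower number from compound 1 to compound 2 (1.04 log units; beyond the scatter) shows. Compound 3, `COc1ccc(-c2ncnc3c2cnn3CCN2CCCCC2)cn1`, is not yet measured. It differs from compound 2 as follows: 6-methoxypyridin-3-yl in place of 4-fluoro-2-methylphenyl on an aromatic carbon. For the measured compounds named here, the only measured step that bears on this change is the one from compound 1 to compound 2, in which the 4-fluoro-2-methylphenyl group brought the large improvement an 11-fold lower number from compound 1 to compound 2 (1.04 log units; beyond the scatter). Compound 3 gives that group up and instead carries a 6-methoxypyridin-3-yl group, which shares its methoxy substituent with the 4-methoxyphenyl of compound 1. Compound 3 is therefore expected to lose much of what compound 2 gained, landing near the level of compound 1, with the step of an 8.3-fold higher number from compound 2 to compound 3 (0.92 log units; beyond the scatter). On that basis compound 3 is estimated at 400 nM, in the range 120 nM to 1500 nM.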

Compound 3, inhibition constant: 38300 nM
Compound 3: the middle estimate sits 96-fold (1.98 log units) below what was measured, and the stated range ends below it.
By their numbers in this assay, from the lowest: compound 2; then compound 1; then compound 3.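

In this assay, the change to 6-methoxypyridin-3-yl in place of 4-fluoro-2-methylphenyl gives an 800-fold higher number from compound 2 to compound 3 (2.90 log units; beyond the scatter), so this aromatic carbon of the shared core tolerates far less than the earlier pair alone revealed. Keeping a methoxy group does not preserve the level of compound 1: 6-methoxypyridin-3-yl in place of 4-methoxyphenyl, which puts a ring nitrogen into the aryl ring, gives a 72-fold higher number from compound 1 to compound 3 (1.86 log units; beyond the scatter) and shows that this one ring atom matters greatly here. No measurement at hand accounts for this loss.

The compounds shown leave open whether a plain pyridin-3-yl group or a 6-methylpyridin-3-yl group would suffer the same loss, or whether it depends on the ring nitrogen together with the methoxy group. They also do not separate the fluorine from the methyl of compound 2, which a 4-fluorophenyl or a 2-methylphenyl group would do.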